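Swapping methoxy for methyl: compound 2 to compound 3

The source may report more compounds than this note shows. Statements on the series, on what has been measured and on what is new or still open speak of the compounds shown alone.

Measured in a functional assay on Huh-7 cells (Homo sapiens) for inhibition, read by MTT assay, with a stated time of 48 h; on this read-out lower numbers stand for stronger inhibition and higher numbers for weaker inhibition:
- Compound 1 `COc1ccc2c(=O)c(/C=C/C(=O)NCc3ccccc3)coc2c1`: 13600 nM
- Compound 2 `COc1ccc(CNC(=O)/C=C/c2coc3cc(OC)ccc3c2=O)cc1`: 7570 nM

Among the compounds with values here, the only measured step is a 1.8-fold lower number from compound 1 to compound 2 (0.25 log units; within the scatter), so compound 2 cannot be separated from compound 1, the only other compound measured. Compound 3 `COc1ccc2c(=O)c(/C=C/C(=O)NCc3ccc(C)cc3)coc2c1` differs from compound 2 by methyl in place of methoxy on an aromatic carbon. Within the data shown here, the one measured step bearing on this change, a 1.8-fold lower number from compound 1 to compound 2 (0.25 log units; within the scatter), concerns the methoxy group and stays within the scatter. No step beyond the scatter is therefore expected in this assay. The estimated change is a 1.2-fold higher number from compound 2 to compound 3 (0.08 log units; within the scatter). Compound 3 is estimated at 9000 nM, with an expected range of 4500 nM to 18000 nM.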

Compound 3, half-maximal inhibitory concentration: 14300 nM
Estimate against measurement, compound 3: 1.6-fold (0.20 log units) below; the measured number falls inside the stated range.
By their numbers in this assay, from the lowest: compounds 2, 1 and 3 (each within the scatter of the next).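

In this assay, the same place on the aromatic ring has now carried three different groups, and none of them stands apart: methyl in place of methoxy gives (a 1.9-fold higher number from compound 2 to compound 3 (0.28 log units; within the scatter)) and methyl in place of hydrogen gives (a 1.1-fold higher number from compound 1 to compound 3 (0.02 log units; within the scatter)). Exchanging these small groups at this place therefore produces no readable difference in this series. No supporting data explain these numbers.

From the compounds shown here alone, whether an amine, a carboxylic acid or a longer chain at this place would move the number beyond the scatter remains open. So does the effect of changes elsewhere on the shared core.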